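Halogen Swap on an Aromatic Ring: Compound 2 to Compound 4

A few compounds are considered here, and "the series" means these few. Any claim that something is new, unique, unknown or untested is made for them only; others in the source may bear on it.

Compound 1 `Cc1nnc(SCC(=O)N/N=c2/scc(-c3ccccc3)n2-c2ccccc2)s1`: 59.2%
Compound 2 `O=C(CSc1nnnn1-c1ccccc1)N/N=c1/scc(-c2ccc(Br)cc2)n1-c1ccccc1`: 20.4%
Compound 3 `Cc1ccc(-c2cs/c(=N/NC(=O)CSc3nncn3C)n2-c2ccccc2)cc1`: 27.8%

In a functional assay on C6 cells (Rattus norvegicus) for cytotoxicity, read by MTT assay, with a stated time of 24 h, tested at 200 ug/mL (a higher number here means a weaker effect of the compound at the concentration tested, a lower number a stronger effect), compound 2 gives 20.4%, the low end of the three numbers: compound 3 sits within the usual scatter of it, while compound 1 stands beyond the scatter with a higher number. Compound 4 `O=C(CSc1nnnn1-c1ccccc1)N/N=c1/scc(-c2ccc(F)cc2)n1-c1ccccc1` has not yet been measured. It differs from compound 2 in one place: fluoro in place of bromo on an aromatic carbon. For the measured compounds named here, no measured pair shows what exchanging one halogen for another does here, so the size of the step in this assay is open; a small rise, not clearly beyond the scatter, seems the most likely outcome. Compound 4 is therefore expected at 30%, within a range from 12% to 55%. That estimate means an expected step of a number 9.6 percentage points higher from compound 2 to compound 4 (within the scatter).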

Compound 4, a percentage reported as activity, at one concentration (the size of the read-out at that concentration, not a potency): 30.6%
For compound 4 the middle estimate is 0.6 percentage points below the measured one, within the range that was stated.
By their numbers in this assay, from the lowest: compounds 2, 3 and 4 (each within the scatter of the next, the first and the last beyond it); then compound 1.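

Among the compounds shown, this is the first pair that differs in one place, so the halogen on this aromatic ring can be read on its own. In this assay the change from 4-bromophenyl to 4-fluorophenyl gives a number 10.2 percentage points higher from compound 2 to compound 4 (beyond the scatter) and so a modest loss of effect at the concentration tested. Nothing available here explains this step. Still open, from the compounds shown here alone, is how chloro, methoxy or an amine would read in the same place, and whether the step holds with other groups elsewhere on the shared core.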